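Chlorophenyl isomer swap on the ring nitrogen: cytotoxicity outlook

The source may report more compounds than this note shows. Statements on the series, on what has been measured and on what is new or still open speak of the compounds shown alone.

Compound 1 `Cc1ccccc1-c1nn(-c2ccc(F)cc2F)cc1CNCCN1CCCCC1` and compound 2 `Cc1ccccc1-c1nn(-c2ccc(Cl)cc2)cc1CNCCN1CCN(C)CC1` share the core of compound 1 and differ in the aryl on the ring nitrogen and in the basic amine at the chain end. In an ADME assay on Huh-7 cells (Homo sapiens) for cytotoxicity (on this read-out lower numbers stand for higher toxicity in this test and higher numbers for lower toxicity in this test), compound 1 returns > 20000 nM, which is a limit of the assay and not a number. In this assay, among the compounds with values here, compound 2 gives 17000 nM, the only number in the pair. The remaining value sits at the limit of > 20000 nM in this assay, at which 1 of the 2 values shown sits. Nothing in these two results separates the aryl from the amine, so no measured step can be read from them.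

Compound 3 `Cc1ccccc1-c1nn(-c2ccccc2Cl)cc1CNCCN1CCN(C)CC1` differs from compound 2 in one place: 2-chlorophenyl in place of 4-chlorophenyl on an aromatic nitrogen. Within the data shown here, no step between measured compounds covers this kind of change, so the expectation rests on compound 2 alone. The expected step is one of no size beyond the scatter, no change at the digits printed from compound 2 to compound 3 (within the scatter). Compound 3 is expected to give 17000 nM, with a range from 8000 nM to 40000 nM, and a reading that returns only a limit is a real possibility.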

Compound 3, half-maximal cytotoxic concentration: > 20000 nM
Compound 3 gave a limit, no number (the forecaster's own chance of this, stated with the estimate: 40%); middle value at least 1.1-fold (0.07 log units) away from the limit.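

Setting 2-chlorophenyl in place of 4-chlorophenyl on the aromatic nitrogen gives, in this assay, an at least 1.1-fold higher number from compound 2 to compound 3 (0.07 log units; that floor lies within the scatter), the first step in the series that changes one place only. At this position, two ring bonds from the ring atom that bears the 2-methylphenyl group, moving the chlorine around the phenyl ring brings no lower number on this read-out, so the change gives no sign of more toxicity toward these cells. The size of the step cannot be fixed beyond its floor, and no order can be set between the two isomers, because the reading for compound 3 is a limit of the assay and not a number: the limit of > 20000 nM in this assay, at which 2 of the 3 values shown sit.

As far as these compounds go, whether 3-chlorophenyl or unsubstituted phenyl on the same nitrogen would give a number in this range remains open. Also open, from the compounds shown here alone, is how far the amine at the chain end counts on its own, since compound 1 and compound 2 differ in two places, and what a longer chain to that amine would do to the reading in this assay.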